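From 3-fluorophenyl to 4-fluorophenyl on the shared core

This account rests on a few compounds, and the source may have more. Where it says the series, first, only, none or still open, it means among the compounds named here.

Of the compounds shown here, three with a shared core have been measured in a functional assay on HL-60 cells (Homo sapiens) for cytotoxicity, read by WST assay, with a stated time of 48 h; a lower number here means that less compound is needed, a higher number that more compound is needed for the effect. Compound 1 `Cc1ccccc1C[C@H]1COC[C@@H]1Cc1ccc(Cl)c(Cl)c1` gives 21000 nM, compound 2 `COc1cccc(C[C@H]2COC[C@@H]2Cc2ccc(Cl)c(Cl)c2)c1` gives 73000 nM, and compound 3 `Fc1cccc(C[C@H]2COC[C@@H]2Cc2ccc(Cl)c(Cl)c2)c1` gives 20000 nM. Compound 3 therefore shares the low end of these numbers with one other compound and stands clearly apart from the third.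

The next compound, compound 4 `Fc1ccc(C[C@H]2COC[C@@H]2Cc2ccc(Cl)c(Cl)c2)cc1`, has 4-fluorophenyl in place of 3-fluorophenyl on a saturated chain carbon bound to a saturated ring carbon. The two have the same atoms, joined differently.

Going by the values given here, no measured step moves a fluoro group, so the evidence is only indirect. Exchanging 2-methylphenyl for 3-fluorophenyl gave a 1.1-fold lower number from compound 1 to compound 3 (0.02 log units; within the scatter). Fluoro in place of methoxy on an aromatic carbon gave a modest change, a 3.7-fold lower number from compound 2 to compound 3 (0.56 log units; beyond the scatter). Only the second of these exceeds the usual variation, and it involves a change of group, which the step to compound 4 does not. No shift beyond the scatter is therefore expected in this assay, and no direction is favoured. The estimated step is a 1.1-fold higher number from compound 3 to compound 4 (0.04 log units; within the scatter). The expected value for compound 4 is 22000 nM, with an estimated range from 10000 nM to 50000 nM.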

Compound 4, half-maximal effective concentration: 43000 nM
The estimate for compound 4 lay 2.0-fold (0.29 log units) below the measured number, within the range that was stated.
By their numbers in this assay, from the lowest: compounds 3 and 1 (each within the scatter of the next); then compounds 4 and 2 (each within the scatter of the next).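

Moving the fluoro group, with the same atoms joined differently, is not silent at this position: in this assay, 4-fluorophenyl in place of 3-fluorophenyl on a saturated chain carbon bound to a saturated ring carbon gives a modest shift (a 2.2-fold higher number from compound 3 to compound 4 (0.33 log units; beyond the scatter)). The earlier exchange of 2-methylphenyl for 3-fluorophenyl stayed within the scatter, whereas exchanging 2-methylphenyl for 4-fluorophenyl at the same place goes beyond it (a 2.0-fold higher number from compound 1 to compound 4 (0.31 log units; beyond the scatter)), so at this place the outcome of such an exchange depends on where the fluoro group sits on the aromatic ring, at least among these compounds. Nothing given here explains why the shift occurs.

As far as these compounds go, whether a 2-fluorophenyl group would fall with 3-fluorophenyl or with 4-fluorophenyl remains open, as does the effect of an amine or a carboxylic acid on the aromatic ring at this place. From the compounds shown here alone, these four compounds also share the same core and were compared in a single cell assay, so it remains open whether the shift between the two fluorophenyl groups would recur on a different core or in other cells.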